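Trifluoromethyl for methyl on a sulfonyl sulfur

This account rests on a few compounds, and the source may have more. Where it says the series, first, only, none or still open, it means among the compounds named here.

In an ADME assay on HEK293 cells (Homo sapiens) for cytotoxicity, read by MTT assay, with a stated time of 48 h (on this read-out lower numbers stand for stronger inhibition and higher numbers for weaker inhibition), compound 2 (`CS(=O)(=O)Nc1ccc(NC(=O)c2ccc(Cl)cc2)cc1Cl`) gives 167000 nM and compound 1 (`Cc1cc(NC(=O)c2ccc(Cl)cc2)ccc1NS(=O)(=O)C(F)(F)F`) gives 201000 nM as its nearest neighbour, the two values lying within the scatter of each other. Compound 3 (`O=C(Nc1ccc(NS(=O)(=O)C(F)(F)F)c(Cl)c1)c1ccc(Cl)cc1`) has trifluoromethyl in place of methyl on a sulfonyl sulfur. Within the data shown here, no measured pair isolates this change, although compound 1 also holds trifluoromethyl on a sulfonyl sulfur. In this assay the expected change a 1.1-fold lower number from compound 2 to compound 3 (0.05 log units; within the scatter) is none beyond the scatter. The estimated value for compound 3 is 150000 nM (expected range 70000 nM to 280000 nM).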

Compound 3, half-maximal inhibitory concentration: 191000 nM
For compound 3 the middle estimate is 1.3-fold (0.10 log units) below the measured one; measured number inside the range.
By their numbers in this assay, from the lowest: compounds 2, 3 and 1 (each within the scatter of the next).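

The pair of compound 2 and compound 3 isolates trifluoromethyl in place of methyl on a sulfonyl sulfur, and this assay shows a 1.1-fold higher number from compound 2 to compound 3 (0.06 log units; within the scatter) for this change. Chloro in place of methyl on an aromatic carbon is isolated as well, with a 1.1-fold lower number from compound 1 to compound 3 (0.02 log units; within the scatter) on the same read-out. Neither change separates the compounds, and no measurement at hand bears on why. Open, going by these compounds, is whether a longer chain or an amine on the sulfonyl sulfur would give a step beyond the scatter. On these data alone, a carboxylic acid on that aromatic carbon remains equally open.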